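The source may report more compounds than this note shows. Statements on the series, on what has been measured and on what is new or still open speak of the compounds shown alone.

Among the measured compounds shown here, compound 2 `CCc1ccc(C(=O)/C=C/c2ccc3c(c2)B(O)OC3)cc1` gives the highest of the two numbers so far in a toxicity assay on WI-38 cells (Homo sapiens) for cytotoxicity, read by MTT assay, with a stated time of 48 h (a higher number here means a weaker inhibitor, a lower number a stronger inhibitor), at 20600 nM. Its nearest neighbour is compound 1 `O=C(/C=C/c1ccc2c(c1)B(O)OC2)c1ccccc1`, which in this assay gives 19100 nM. These two differ by ethyl in place of hydrogen on an aromatic carbon, a step of a 1.1-fold higher number from compound 1 to compound 2 (0.03 log units; within the scatter).

Compound 3 `O=C(/C=C/c1ccc2c(c1)B(O)OC2)c1ccc([N+](=O)[O-])cc1` carries nitro in place of ethyl on an aromatic carbon, sitting on an aromatic carbon of a six-membered aromatic ring of carbon only, para to a large group. For the measured compounds named here, the only measured step at this position, a 1.1-fold higher number from compound 1 to compound 2 (0.03 log units; within the scatter), was small, so no step beyond the scatter is expected in this assay for compound 3 either. The expected step is a 1.0-fold lower number from compound 2 to compound 3 (0.01 log units; within the scatter). Compound 3 is therefore estimated at 20000 nM in this assay, with a range from 8000 nM to 50000 nM. Neither measured compound probes a nitro group, so the estimate rests on that single step alone.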

Compound 3, half-maximal inhibitory concentration: 39300 nM
For compound 3 the middle estimate is 2.0-fold (0.29 log units) below the measured one, within the range that was stated.
By their numbers in this assay, from the lowest: compounds 1, 2 and 3 (each within the scatter of the next, the first and the last beyond it).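

Among the compounds shown here, on an aromatic carbon para to a large group, nitro gives the first change in this assay that clears the scatter, with a 2.1-fold higher number from compound 1 to compound 3 (0.31 log units; beyond the scatter) in place of hydrogen, though the step is only modest. Against ethyl the same change gives a 1.9-fold higher number from compound 2 to compound 3 (0.28 log units; within the scatter) and so stays unresolved, which means compound 3 and compound 2 cannot be ranked at this position and only the comparison with hydrogen separates nitro from the unsubstituted compound. Nothing available explains this difference between the two groups.

The compounds shown leave open whether an amine or a carboxylic acid on this aromatic carbon would give a step of similar size. As far as these compounds go, it also remains open whether a longer chain than ethyl would stay within the scatter of compound 1.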